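Moving the fluorine on the phenyl ring of a succinimide piperazine amide

The compounds below may be only part of what the source reports. "The series", "measured", "known", "first", "only" and "open" are said of these compounds alone.

Compound 3, with the structure `CC(C(=O)N1CCN(c2ccccc2F)CC1)N1C(=O)CCC1=O`, is the strongest of three compounds tested in a functional assay on the whole organism (strain Swiss) with Mus musculus as the target, in the maximal electroshock model, with a stated time of 2 h, at a dose of 300 mg/kg by the intraperitoneal route; on this read-out higher numbers stand for a stronger effect at the one dose given and lower numbers for a weaker effect. Compound 3 gives 25%. Compound 1, `CC(C(=O)N1CCN(c2ccc(Cl)cc2)CC1)N1C(=O)CCC1=O`, gives 0%, and compound 2, `CCC(C(=O)N1CCN(c2cccc(F)c2)CC1)N1C(=O)CCC1=O`, gives 0%. The only single-point step among these is a number 25 percentage points higher from compound 1 to compound 3 (beyond the scatter), so the 2-fluorophenyl group has gone with the one measurable effect in this small set.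

Compound 4, `CC(C(=O)N1CCN(c2cccc(F)c2)CC1)N1C(=O)CCC1=O`, has not yet been measured. It differs from compound 3 by 3-fluorophenyl in place of 2-fluorophenyl on an amine nitrogen in a ring. Among the compounds with values here, no measured step covers this exact exchange. Within the data shown here, what the numbers do offer is compound 2, which already carries a 3-fluorophenyl group, though on a different chain, and is inactive in this assay, while the one compound with activity, compound 3, carries the 2-fluorophenyl group. On that basis a fall is expected, so that the step of a number 20 percentage points lower from compound 3 to compound 4 (beyond the scatter) is estimated to take the value back toward the inactive compounds. Compound 4 is therefore expected to give about 5% in this assay, with a plausible span from 0% to 25%.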

Compound 4, a percentage reported as activity, at one dose (the size of the read-out at that dose, not a potency): 100%
Compound 4: the middle estimate sits 95 percentage points below what was measured; the measured number lies above the stated range.
By their numbers in this assay, from the lowest: compounds 1 and 2 (each within the scatter of the next); then compound 3; then compound 4.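

In this assay, within the data shown here, moving one fluorine on the phenyl ring, with the same atoms joined differently, gives a number 75 percentage points higher from compound 3 to compound 4 (beyond the scatter) when 3-fluorophenyl takes the place of 2-fluorophenyl, so the place of the fluorine matters far more than the earlier compounds could reveal. The 3-fluorophenyl group is not enough by itself, as compound 2 also carries it: hydrogen in place of methyl on the saturated chain carbon gives a number 100 percentage points higher from compound 2 to compound 4 (beyond the scatter) and shows that this chain position matters as well. Starting from the 4-chlorophenyl group, the 3-fluorophenyl exchange gives a number 100 percentage points higher from compound 1 to compound 4 (beyond the scatter) in the core of compound 1, while the 2-fluorophenyl exchange gave a number 25 percentage points higher from compound 1 to compound 3 (beyond the scatter) in that same core.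

Nothing available here explains why either the place of the fluorine or the small chain change has so large an effect. Going by these compounds, it remains open whether a 3-chlorophenyl or 3-methoxyphenyl group on the same amine nitrogen would keep this high read-out, and, as each number comes from a single dose, how the compounds would compare in potency.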